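From 2-(methoxycarbonyl)pyrrolidin-1-yl to morpholin-4-yl

The source may report more compounds than this note shows. Statements on the series, on what has been measured and on what is new or still open speak of the compounds shown alone.

In an in vivo functional assay on the whole organism for inhibition, with Rattus norvegicus as the target (a higher number here means that more compound is needed for the effect, a lower number that less compound is needed), compound 1 (`CCCc1nc(C)c(CC(=O)O)c(=O)n1Cc1ccc(-c2ccccc2-c2nnn[nH]2)cc1`) stands as "not determined" (no result reported) and so offers no number for comparison. Compound 2 (`CCCCc1nc(C)c(CC(=O)N(CC)CC)c(=O)n1Cc1ccc(-c2ccccc2-c2nnn[nH]2)cc1`) gives 0.089 mg/kg and compound 3 (`CCCCc1nc(C)c(CC(=O)N2CCC[C@H]2C(=O)OC)c(=O)n1Cc1ccc(-c2ccccc2-c2nnn[nH]2)cc1`) gives 0.043 mg/kg as the lower of the two numbers, which means that less of compound 3 is needed for the effect.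

The next structure, compound 4 (`CCCCc1nc(C)c(CC(=O)N2CCOCC2)c(=O)n1Cc1ccc(-c2ccccc2-c2nnn[nH]2)cc1`), carries morpholin-4-yl in place of 2-(methoxycarbonyl)pyrrolidin-1-yl on a carbonyl carbon. The rest of the molecule stays the same.

Among the compounds with values here, only one measured step bears on this change. It is a 2.1-fold lower number from compound 2 to compound 3 (0.32 log units; beyond the scatter) and it came with 2-(methoxycarbonyl)pyrrolidin-1-yl in place of diethylamino at that same carbonyl carbon. This step is modest but beyond the usual scatter. Compound 4 gives up the same group, so the number may well drift back towards that of compound 2 at 0.089 mg/kg even though morpholin-4-yl is not diethylamino. Within the data shown here, no measured compound yet carries morpholin-4-yl, so this guide is thin. Among the measured compounds shown here, a modest move to a higher number is expected, estimated as a 1.9-fold higher number from compound 3 to compound 4 (0.27 log units; within the scatter) (a size close to the one measured step). For compound 4 the estimated value is 0.08 mg/kg (expected range 0.03 mg/kg to 0.22 mg/kg).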

Compound 4, dose for half-maximal effect: 0.018 mg/kg
For compound 4 the middle estimate is 4.4-fold (0.65 log units) above the measured one; measured number outside the range, below it.
By their numbers in this assay, from the lowest: compound 4; then compound 3; then compound 2.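

In this assay the change brings a 2.4-fold lower number from compound 3 to compound 4 (0.38 log units; beyond the scatter), so leaving the 2-(methoxycarbonyl)pyrrolidin-1-yl group does not return the number towards that of the diethylamino amide. Set directly against that amide, morpholin-4-yl gives a 4.9-fold lower number from compound 2 to compound 4 (0.69 log units; beyond the scatter) and leaves compound 4 with the lowest number of the three compounds that have one. This carbonyl carbon therefore tolerates a wider spread of amine groups than the earlier pair could show, and a low number here needs neither a methoxycarbonyl group nor a defined stereocentre, since morpholin-4-yl, with its six heavy atoms, carries neither.

Still open, as far as these compounds go, is whether the ring oxygen of morpholin-4-yl matters, a question that a piperidin-1-yl ring, or a piperazin-1-yl ring with its extra amine, at this same carbonyl carbon would address. No measurement of any other property accompanies these numbers, and the reason for the shift remains unknown.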